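The source may hold more compounds than are shown below. What is called first, only, known or untested is meant among the compounds shown, and "the series" means these compounds.

Measured so far:
Compound 1, `Fc1ccc2nc(-c3ccccc3)nc(Nc3ccccc3)c2c1` — > 50000 nM in a functional assay on HL-60 cells (Homo sapiens) for cytotoxicity, read by MTT assay, with a stated time of 48 h; a higher number here means a weaker inhibitor, a lower number a stronger inhibitor
Compound 2, `Fc1ccc(Nc2nc(-c3cccc(F)c3)nc3ccc(F)cc23)cc1` — > 50000 nM in this assay

In this assay compound 1 gives > 50000 nM, which is a limit of the assay and not a number. Compound 2 likewise gives > 50000 nM in this assay, again a limit rather than a number. Where compound 2 stands is therefore set by the limit of > 50000 nM in this assay, at which 2 of the 2 values shown sit, and nothing more can be said of either compound than that neither reaches a measurable value there.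

Compound 3, `Fc1cccc(-c2nc(Nc3ccc(Br)cc3)c3cc(F)ccc3n2)c1`, has not yet been measured. It differs from compound 2 by bromo in place of fluoro on an aromatic carbon. Within the data shown here, no step between measured compounds is available, so the size of such a change cannot be read from the two values in hand. Given that compound 2 gives only a limit, > 50000 nM in this assay, compound 3 is expected to remain at or near that limit, and the step of a number no higher from compound 2 to compound 3 (the limit leaves the size open) is expected to be none beyond the usual scatter. The estimate for compound 3 in this assay is 50000 nM, with a range from 15000 nM to 200000 nM.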

Compound 3, half-maximal inhibitory concentration: > 50000 nM
Compound 3: no number, only a limit; the forecaster's own chance of this, stated with the estimate: 75%; the middle value sits exactly at the limit.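

In this assay compound 3 gives > 50000 nM, which is a limit and not a number. Compound 2 also stands at a limit, so no step can be read between compound 2 and compound 3 for bromo in place of fluoro. The compounds shown leave open whether any of them has a measurable value in this assay: the limit of > 50000 nM in this assay, at which 3 of the 3 values shown sit.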